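Replacing tert-butyl with trifluoromethyl in compound 3

The source may hold more compounds than are shown below. What is called first, only, known or untested is meant among the compounds shown, and "the series" means these compounds.

Values measured in a functional assay on HUVEC cells (Homo sapiens) for inhibition, with a stated time of 4 days; on this read-out lower numbers stand for stronger inhibition and higher numbers for weaker inhibition:
Compound 1 `Cc1cc(OCc2cccc(C#N)c2)ccc1Cl`: 11000 nM
Compound 2 `COc1ccc(C(=O)O)cc1COc1ccc(Cl)c(C)c1`: > 50000 nM (a limit, not a number)
Compound 3 `COc1ccc(C(N)=O)cc1/C=C/c1ccc(C(C)(C)C)cc1`: 370 nM

Among the two exact numbers in this assay, compound 3 (370 nM) stands lowest. Compound 1 gives 11000 nM and the gap between these two compounds lies beyond the scatter. Compound 4 `COc1ccc(C(N)=O)cc1/C=C/c1ccc(C(F)(F)F)cc1` carries trifluoromethyl in place of tert-butyl on an aromatic carbon. For the measured compounds named here, no measured pair shows this exchange, so the expectation is tentative. A moderate move toward a higher number, beyond the scatter, is expected, with the estimated size being a 2.7-fold higher number from compound 3 to compound 4 (0.43 log units; beyond the scatter) in this assay. For compound 4 the expected value is 1000 nM, within an estimated range from 250 nM to 5000 nM.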

Compound 4, half-maximal inhibitory concentration: 880 nM
Compound 4: middle estimate off by 1.1-fold (0.06 log units), on the high side; the range from low to high includes it.
By their numbers in this assay, from the lowest: compound 3; then compound 4; then compound 1. At a limit, above all of these: compound 2.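

In this assay, for the compounds shown here, trifluoromethyl in place of tert-butyl gives a 2.4-fold higher number from compound 3 to compound 4 (0.38 log units; beyond the scatter), the only step here between compounds that differ in one place. It shows that the read-out responds to the group at this position, though only modestly, and that compound 4 keeps a value of 880 nM with trifluoromethyl there. Nothing available here accounts for this step. As far as these compounds go, how an amine or a cyclopropyl group would fare at this position remains open. So does whether the step would have the same size on another core.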